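A few compounds are considered here, and "the series" means these few. Any claim that something is new, unique, unknown or untested is made for them only; others in the source may bear on it.

Working notes on the series, followed in a functional assay on L1210 cells (Mus musculus) for inhibition, read by cell counting, with a stated time of 2 days; a lower number here means a stronger inhibitor, a higher number a weaker inhibitor. Compound 1, `Nc1cccc(-c2cn3nc(-c4cccs4)sc3n2)c1`, shows only a limit of the assay there, > 250000 nM, and no number. Going by the values given here, compound 2, `C=C(Br)C(=O)Nc1cccc(-c2cn3nc(-c4ccc(F)cc4)sc3n2)c1`, gives 250 nM in this assay; this is the only number in the set so far. The other value shown, for compound 1, is the limit of > 250000 nM in this assay, at which 1 of the 2 values shown sits. Compound 3, `C=C(Br)C(=O)Nc1cccc(-c2cn3nc(-c4ccc(OC)cc4)sc3n2)c1`, is not yet measured. It differs from compound 2 in one place: methoxy in place of fluoro on an aromatic carbon. Among the compounds with values here, no step between two measured compounds covers this kind of change, so the expectation rests on compound 2 alone, and a move within the usual scatter is expected, with no fixed direction. The step in this assay is estimated as a 1.2-fold higher number from compound 2 to compound 3 (0.08 log units; within the scatter). Compound 3 is accordingly expected to give about 300 nM in this assay, with a range from 100 nM to 1000 nM.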

Compound 3, half-maximal inhibitory concentration: 940 nM
The estimate for compound 3 lay 3.1-fold (0.50 log units) below the measured number; low and high end bracket the measured number.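

Methoxy in place of fluoro on an aromatic carbon, para to a large group, gives a 3.8-fold higher number from compound 2 to compound 3 (0.58 log units; beyond the scatter) in this assay and is the first single change in the series that can be read. This position is not silent: changing this one substituent moves the number towards a weaker inhibitor, while compound 3 still gives a measured number and not a limit. No measurement shown bears on why the number moves.

With only fluoro and methoxy shown at this position, a chloro, hydroxy or dimethylamino group there remains open. Compound 1 shows only a limit of the assay, > 250000 nM, and differs from the other compounds in more than one place, leaving its amine open as a single change.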